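The compounds below may be only part of what the source reports. "The series", "measured", "known", "first", "only" and "open" are said of these compounds alone.

In a functional assay on MCF7 cells (Homo sapiens) for antiproliferative activity, with a stated time of 5 days (on this read-out higher numbers stand for weaker inhibition and lower numbers for stronger inhibition), compound 1 `CCCCc1ccc2[nH]c(-c3ccc(C)cc3)c(C=O)c2c1` gives 54 nM, compound 2 `CCCCc1ccc2[nH]c(-c3ccc(C(F)(F)F)cc3)c(C=O)c2c1` gives 66 nM and compound 3 `CCCCCc1ccc2[nH]c(-c3ccc(C(F)(F)F)cc3)c(C=O)c2c1` gives 67 nM. Compound 2 therefore stands within the scatter of both other compounds, and the three numbers cannot be separated. Compound 4 `CCCCc1ccc2[nH]c(-c3ccc(C(F)(F)F)cc3)c(/C=N\C)c2c1` differs from compound 2 at the formyl group, on an aromatic carbon of a five-membered aromatic ring with 1 nitrogen: a group of 3 heavy atoms (2 carbon, 1 nitrogen; no ring) in place of a group of 2 heavy atoms (1 carbon, 1 oxygen; no ring), on an aromatic carbon.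

Among the compounds with values here, two measured steps bear on this only indirectly. Trifluoromethyl in place of methyl on an aromatic carbon gives a 1.2-fold higher number from compound 1 to compound 2 (0.09 log units; within the scatter), and methyl in place of hydrogen on a saturated chain carbon gives a 1.0-fold higher number from compound 2 to compound 3 (0.01 log units; within the scatter). Neither step touches the formyl group, so the series holds no measured change at this place. A modest move towards a higher number in this assay is expected, with the direction uncertain. The expected step is a 1.7-fold higher number from compound 2 to compound 4 (0.22 log units; within the scatter). For compound 4 the estimated value is 110 nM, with an expected range of 30 nM to 500 nM.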

Compound 4, half-maximal inhibitory concentration: 140 nM
Beside the measured number, compound 4's estimate is 1.3-fold (0.10 log units) below it; low and high end bracket the measured number.
By their numbers in this assay, from the lowest: compounds 1, 2 and 3 (each within the scatter of the next); then compound 4.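

At the formyl position, on an aromatic carbon of a five-membered aromatic ring with 1 nitrogen, the series now has its first measured change. In this assay, the group of 3 heavy atoms in place of formyl gives a 2.1-fold higher number from compound 2 to compound 4 (0.33 log units; beyond the scatter), the only step among those shown that lies beyond the scatter, whereas the earlier trifluoromethyl and chain steps both lie within it. No measured evidence accounts for this step.

This single replacement changes the atom count and puts nitrogen in place of oxygen together, so the contribution of each remains unresolved. Also open, from the compounds shown here alone, is how the number responds at this place to a carboxylic acid, a primary amide or a hydroxymethyl group, and whether the step holds with methyl in place of trifluoromethyl or on the longer chain of compound 3.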